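The source may hold more compounds than are shown below. What is called first, only, known or untested is meant among the compounds shown, and "the series" means these compounds.

Working notes on the series. The measured compounds share one core, seen in compound 1 `Cc1cc2c(cc1C)C(Cl)=C(/C=N/NC(=O)c1ccccc1)CCC2`, compound 2 `Cc1ccc(C(=O)N/N=C/C2=C(Cl)c3cc(C)c(C)cc3CCC2)cc1` and compound 3 `COc1cccc(C(=O)N/N=C/C2=C(Cl)c3cc(C)c(C)cc3CCC2)c1C`, and differ only in the aryl group on the carbonyl carbon. In a functional assay (MiaPaCa cells, Homo sapiens) for inhibition, read by sulforhodamine B assay, with a stated time of 48 h (on this read-out lower numbers stand for stronger inhibition of growth and higher numbers for weaker inhibition of growth), compound 1 reaches only a limit of the assay, > 100000 nM. In this assay compound 2 gives 28800 nM, while compound 3 gives 2000 nM, the lowest of the two numbers reported. The steps run an at least 3.4-fold lower number from compound 1 to compound 2 (0.54 log units; beyond the scatter), an at least 50-fold lower number from compound 1 to compound 3 (1.69 log units; beyond the scatter) and a 14-fold lower number from compound 2 to compound 3 (1.16 log units; beyond the scatter); the two steps that start from compound 1 rest on the limit of > 100000 nM in this assay, at which 1 of the 3 values shown sits, and are therefore known only as minimum sizes.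

Compound 4 `Cc1cc2c(cc1C)C(Cl)=C(/C=N/NC(=O)c1cccc(Cl)c1)CCC2` carries the change (3-chlorophenyl in place of 3-methoxy-2-methylphenyl on a carbonyl carbon). Going by the values given here, the steps that bear on it are the aryl swaps on the carbonyl carbon, a 14-fold lower number from compound 2 to compound 3 (1.16 log units; beyond the scatter) and an at least 50-fold lower number from compound 1 to compound 3 (1.69 log units; beyond the scatter), both large, with the 3-methoxy-2-methylphenyl compound at the low end in each. Compound 4 gives up that group for a 3-chlorophenyl with no hydrogen-bond acceptor, a pattern closer to compound 2 than to compound 3, so a step beyond the scatter toward higher numbers in this assay is expected, though not a return to the limit seen for compound 1. Compound 4 is expected near 15000 nM, between 3000 nM and 70000 nM, which means an estimated step of a 7.5-fold higher number from compound 3 to compound 4 (0.88 log units; beyond the scatter).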

Compound 4, concentration for 50% growth inhibition: 33600 nM
Estimate against measurement, compound 4: 2.2-fold (0.35 log units) below; the range from low to high includes it.
By their numbers in this assay, from the lowest: compound 3; then compounds 2 and 4 (each within the scatter of the next). At a limit, above all of these: compound 1.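

In this assay, 3-chlorophenyl in place of 3-methoxy-2-methylphenyl on a carbonyl carbon gives a 17-fold higher number from compound 3 to compound 4 (1.23 log units; beyond the scatter), so the low number of compound 3 does not carry over to this other substituted phenyl. Against 4-methylphenyl the same swap gives a 1.2-fold higher number from compound 2 to compound 4 (0.07 log units; within the scatter), so these two substituted phenyl groups are not told apart here, and among the compounds with a measured number only 3-methoxy-2-methylphenyl stands clear of the rest. The chloro on the phenyl group also moves the number, an at least 2.9-fold lower number from compound 1 to compound 4 (0.47 log units; beyond the scatter), but that size is only a minimum, as compound 1 is a limit of the assay and not a number: the limit of > 100000 nM in this assay, at which 1 of the 4 values shown sits.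

The compounds shown leave open whether the methoxy, the methyl or the two together carry the step to compound 3, as the group that leaves differs from 3-chlorophenyl in more than one respect. They also leave open what a hydroxy or an amine in place of the methoxy would give on the same core.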